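Methyl to methoxy on the terminal aryl urea

The source may hold more compounds than are shown below. What is called first, only, known or untested is meant among the compounds shown, and "the series" means these compounds.

Compound 2 `Cc1ccc(NC(=O)Nc2cccc(CNc3ncnc4ccccc34)c2)cc1` gives 31200 nM in a functional assay on MGC-803 cells (Homo sapiens) for antiproliferative activity, read by MTT assay; on this read-out higher numbers stand for weaker inhibition and lower numbers for stronger inhibition. Going by the values given here, the only other number so far comes from compound 1 `Cc1cccc(NC(=O)Nc2cccc(CNc3ncnc4ccccc34)c2)c1`, which gives 30200 nM in this assay; the step of a 1.0-fold higher number from compound 1 to compound 2 (0.01 log units; within the scatter) lies within the scatter, so the two compounds stand together rather than in any order. Compound 3 `COc1ccc(NC(=O)Nc2cccc(CNc3ncnc4ccccc34)c2)cc1` differs from compound 2 by methoxy in place of methyl on an aromatic carbon, para to a large group. Among the compounds with values here, the one measured step, from compound 1 to compound 2, exchanges 4-methylphenyl for 3-methylphenyl on the amide-type nitrogen and stays within the scatter; no measured step replaces methyl by methoxy, so there is no direct precedent for this change. On that basis no movement beyond the scatter is expected, a 1.0-fold lower number from compound 2 to compound 3 (0.00 log units; within the scatter). Compound 3 is therefore estimated at 31000 nM in this assay, with a range from 15000 nM to 62000 nM.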

Compound 3, half-maximal inhibitory concentration: 27300 nM
Beside the measured number, compound 3's estimate is 1.1-fold (0.06 log units) above it, within the range that was stated.
By their numbers in this assay, from the lowest: compounds 3, 1 and 2 (each within the scatter of the next).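

In this assay, methoxy in place of methyl at this position, para to a large group, adds one heavy atom and one hydrogen-bond acceptor, and the number stays within the scatter (from a 1.1-fold lower number from compound 2 to compound 3 (0.06 log units; within the scatter)). The comparison with the 3-methylphenyl urea also stays within the scatter (from a 1.1-fold lower number from compound 1 to compound 3 (0.04 log units; within the scatter)), so the 3-methylphenyl, 4-methylphenyl and 4-methoxyphenyl ureas stand together, with no order among them. Nothing available bears on the reason for this result.

The compounds shown leave open whether any group on this terminal ring can move the number beyond the scatter, for example a carboxylic acid, an amine or a longer alkoxy chain. They also leave open how much the urea linker and the shared core contribute to the activity.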